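This account rests on a few compounds, and the source may have more. Where it says the series, first, only, none or still open, it means among the compounds named here.

Three compounds sharing one core were examined in a functional assay on CHO cells for positive allosteric modulation of muscarinic acetylcholine receptor M5 (Homo sapiens), read by FLIPR and calcium flux, with a stated time of 1 h; on this read-out lower numbers stand for an effect already at smaller amounts and higher numbers for an effect only at larger amounts of compound. Compound 2 `O=C1C(=O)N(Cc2ccc(-c3ccccc3)cn2)c2ccc(OC(F)(F)F)cc21` gives 3100 nM. Compound 3 `O=C1C(=O)N(Cc2ccc(-c3ccccc3)cc2)c2ccc(OC(F)(F)F)cc21` gives 1600 nM, a value that sits within the scatter of that of compound 2. For compound 1 `O=C1C(=O)N(Cc2ccc(-c3ccncc3)cn2)c2ccc(OC(F)(F)F)cc21` the assay returns only a limit, > 30000 nM. The change pyridin-4-yl in place of phenyl on an aromatic carbon thus brought an at least 9.6-fold higher number from compound 2 to compound 1 (0.98 log units; beyond the scatter), a step that rests on (the limit of > 30000 nM in this assay, at which 1 of the 3 values shown sits). How the cores of compound 2 and compound 3 differ is not broken down here. Compound 4 `O=C1C(=O)N(Cc2ccc(-c3ccncc3)cc2)c2ccc(OC(F)(F)F)cc21` carries the same kind of change relative to compound 3, namely (pyridin-4-yl in place of phenyl on an aromatic carbon); here the place is a six-membered aromatic ring of carbon only, whereas in compound 1 it is a ring with one nitrogen, two atoms from the ring nitrogen. Compound 4 is expected to show an 11-fold higher number from compound 3 to compound 4 (1.05 log units; beyond the scatter). That expectation rests on an at least 9.6-fold higher number from compound 2 to compound 1 (0.98 log units; beyond the scatter). Compound 4 is estimated at 18000 nM, between 5000 nM and 30000 nM, with a fair chance that only a limit is returned.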

Compound 4, half-maximal effective concentration: 2800 nM
Estimate against measurement, compound 4: 6.4-fold (0.81 log units) above, and the stated range ends above it.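

In this assay, pyridin-4-yl in place of phenyl brought a 1.8-fold higher number from compound 3 to compound 4 (0.24 log units; within the scatter), so on the core of compound 3 the change gave no step beyond the scatter. Set beside the earlier step, the change did not carry over in size from one core to the other: the same change on two cores in this assay, an at least 9.6-fold higher number (0.98 log units; beyond the scatter) from compound 2 to compound 1 and a 1.8-fold higher number (0.24 log units; within the scatter) from compound 3 to compound 4, at least 5.5-fold (0.74 log units) apart, beyond the scatter of two such steps What lies behind this difference is not shown, and the earlier step has no fixed size, since its end point is a limit and not a number: the limit of > 30000 nM in this assay, at which 1 of the 4 values shown sits.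

The two pairs leave open how these cores would respond to other groups in place of phenyl, such as a morpholine or a carboxylic acid. From the compounds shown here alone, whether the same gap would appear on further cores also remains open.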